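Chain change from compound 2 to compound 3

The source may hold more compounds than are shown below. What is called first, only, known or untested is meant among the compounds shown, and "the series" means these compounds.

In a functional assay on HT-29 cells (Homo sapiens) for antiproliferative activity, read by MTT assay, with a stated time of 72 h (on this read-out lower numbers stand for stronger inhibition and higher numbers for weaker inhibition), compound 1 (`CCn1ccnc1-c1cc(OC)c(OC)c(OC)c1`) gives > 100000 nM as a limit of the assay. Compound 2 (`COc1cc(-c2nccn2CC(C)C)cc(OC)c1OC`) gives > 100000 nM as a limit too, so it has no number. With the limit of > 100000 nM in this assay, at which 2 of the 2 values shown sit, the series has no number yet. Compound 3 (`CCCCCn1ccnc1-c1cc(OC)c(OC)c(OC)c1`) differs from compound 2 by butyl in place of isopropyl on a saturated chain carbon bound to an aromatic nitrogen. Within the data shown here, the one measured step (a step that the two limits leave unreadable from compound 1 to compound 2) gives no size to carry over. In this assay no step beyond the scatter is expected in either direction, and the estimate is a number no higher from compound 2 to compound 3 (the limit leaves the size open) for this change. For compound 3 the estimated value is 100000 nM within an expected range (30000 nM to 300000 nM).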

Compound 3, half-maximal inhibitory concentration: 60100 nM
Compound 3: middle estimate off by 1.7-fold (0.22 log units), on the high side; low and high end bracket the measured number.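

In this assay, among these compounds, compound 3 gives the first actual number, so a change at this position on a saturated chain carbon bound to an aromatic nitrogen can now be given a floor. Both an at least 1.6-fold lower number from compound 2 to compound 3 (0.22 log units; that floor lies within the scatter) and an at least 1.6-fold lower number from compound 1 to compound 3 (0.22 log units; that floor lies within the scatter) are floors rather than sizes, and neither shows a change beyond the scatter. The rest of the series remains at a limit: the limit of > 100000 nM in this assay, at which 2 of the 3 values shown sit.

From the compounds shown here alone, the true size of either step remains open. So does whether a longer chain, or a chain ending in an amine or a carboxylic acid, at this position would give a step beyond the scatter.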